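The source may hold more compounds than are shown below. What is called first, only, known or untested is meant among the compounds shown, and "the series" means these compounds.

Measured compounds:
Compound 1, `Nc1cc(N)c2nc(-c3ccccc3)c(NCc3ccc(Cl)c(Cl)c3)nc2c1`; in a functional assay on OVCAR-4 cells (Homo sapiens) for inhibition, read by sulforhodamine B assay, with a stated time of 48 h (a lower number here means that less compound is tolerated, a higher number that more compound is tolerated), compound 1 gives only a limit, < 100000 nM.
Compound 2, `Nc1cc(N)c2nc(-c3ccccc3)c(NCc3ccc(F)cc3)nc2c1`; in this assay compound 2 gives 60300 nM.

Going by the values given here, compound 2 thus holds the only number in this assay; the other value shown is a limit. The step that the limit leaves unreadable from compound 1 to compound 2 cannot be read because of the limit of < 100000 nM in this assay, at which 1 of the 2 values shown sits. Compound 3, `COc1ccc(CNc2nc3cc(N)cc(N)c3nc2-c2ccccc2)cc1`, differs from compound 2 in one place: methoxy in place of fluoro on an aromatic carbon. Among the compounds with values here, no measured step shares this change, and the one step recorded between the measured compounds is unreadable, so nothing among them points in either direction for this exchange. Compound 3 is expected to show a step of a 1.0-fold lower number from compound 2 to compound 3 (0.00 log units; within the scatter), which is estimated to stay within the scatter. Compound 3 is estimated at 60000 nM in this assay, with a range from 25000 nM to 150000 nM, and with a real chance that only a limit is reported.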

Compound 3, concentration lethal to 50% of the cells: 47900 nM
The estimate for compound 3 lay 1.3-fold (0.10 log units) above the measured number, within the range that was stated.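

In this assay, going by these compounds alone, the exchange of fluoro for methoxy on the aromatic carbon, para to a large group, gives the first readable step, a 1.3-fold lower number from compound 2 to compound 3 (0.10 log units; within the scatter). At this position, therefore, the two groups cannot be told apart in this read-out, even though the methoxy adds a hydrogen-bond acceptor that the fluoro lacks. The steps from compound 1 still cannot be read, as its value is only a limit: the limit of < 100000 nM in this assay, at which 1 of the 3 values shown sits.

From the compounds shown here alone, how an amine or a carboxylic acid at this position would read remains open, as does whether a longer chain on the oxygen, such as ethoxy, would move the number beyond the scatter. The compounds shown also leave open what a change on the shared core or its phenyl group would do.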